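Ester-to-amide change at the chain terminus of compound 1

The source may report more compounds than this note shows. Statements on the series, on what has been measured and on what is new or still open speak of the compounds shown alone.

Measured compounds in a physicochemical assay for lipophilicity; on this read-out higher numbers stand for higher lipophilicity and lower numbers for lower lipophilicity:
compound 1 `COC(=O)/C=C(C)/C=C/CC(C)CCCC(C)C`: 6.2
compound 2 `COC(=O)/C=C(C)/C=C/CC(C)CCCC(C)(C)OC`: 5
compound 3 `C=C(C)CCCC(C)C/C=C/C(C)=C/C(=O)OCC`: 6.19

Compound 1 stands highest of the three numbers in this assay, but its gap to compound 3 is within the scatter, so no order between compound 1 and compound 3 can be read from these values. For the measured compounds named here, only compound 2 sits clearly apart: the step of a number 1.20 log units lower from compound 1 to compound 2 (beyond the scatter) is large and beyond the scatter, and it is the only step between measured compounds that differ in one place.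

Compound 4 `CC(/C=C/CC(C)CCCC(C)C)=C\C(=O)NCC(C)C` is not yet measured. It differs from compound 1 as follows: isobutylamino in place of methoxy on a carbonyl carbon. Going by the values given here, the one measured step, from compound 1 to compound 2, concerns a methoxy in place of hydrogen on a saturated chain carbon, not the carbonyl carbon, so it does not bear on this change, and no measured pair shows an isobutylamino in place of methoxy. The expectation therefore rests on the counted difference alone: more heavy atoms enter than leave, while a hydrogen-bond acceptor is traded for a hydrogen-bond donor. A modest step upward in this assay is expected, though a step within the scatter cannot be ruled out. For compound 4 the estimate is 6.6, with a range from 6 to 7.2, meaning an expected step of a number 0.40 log units higher from compound 1 to compound 4 (beyond the scatter).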

Compound 4, partition coefficient: 6.19
Compound 4: middle estimate off by 0.41 log units, on the high side; low and high end bracket the measured number.
By their numbers in this assay, from the lowest: compound 2; then compounds 3, 4 and 1 (each within the scatter of the next).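

In this assay, isobutylamino in place of methoxy on a carbonyl carbon gives a number 0.01 log units lower from compound 1 to compound 4 (within the scatter) and so marks this position as one where more heavy atoms can enter than leave, with a hydrogen-bond acceptor traded for a hydrogen-bond donor, without a step beyond the scatter. For the compounds shown here, the earlier compounds held only one readable step, a number 1.20 log units lower from compound 1 to compound 2 (beyond the scatter) for methoxy in place of hydrogen on a saturated chain carbon, and that step is large, so the two places in the chain now read differently in this assay: one step lies beyond the scatter and the other within it. No measurement at hand gives a reason for the result at the carbonyl carbon.

Still open, going by these compounds, is whether the outcome belongs to isobutylamino itself or holds for the carbonyl carbon more widely, which a carboxylic acid, an ethylamino group or a longer chain on the amide nitrogen at the same place would test. Also open, on these data alone, is whether the isobutylamino change and the methoxy on the saturated chain carbon of compound 2 would add up when both stand in one compound.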